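Swapping an allyl for an amide on a pyrrolidine core

The source may hold more compounds than are shown below. What is called first, only, known or untested is meant among the compounds shown, and "the series" means these compounds.

Measured so far:
Compound 1, `C=CC[C@@H]1CN[C@H](C(=O)N2CCC[C@H]2C#N)C1`, gives 38% in an assay on the whole organism (plasma, strain Sprague-Dawley) for inhibition of Dipeptidyl peptidase 4 (Rattus norvegicus), with a stated time of 6 h, at a dose of 1 mg/kg by the oral route; on this read-out lower numbers stand for less inhibition and higher numbers for more inhibition at the one dose given (going by the name of the read-out).
Compound 2, `C[C@@H]1N[C@H](C(=O)N2CCC[C@H]2C#N)C[C@@H]1C(=O)N1CCC1`, gives 94% in this assay.

Compound 1 stands at the lower of the two numbers; compound 2 lies far higher, beyond the scatter. Compound 3, `CCN(CC)C(=O)[C@@H]1CN[C@H](C(=O)N2CCC[C@H]2C#N)C1`, carries diethylcarbamoyl in place of allyl on a saturated ring carbon. For the measured compounds named here, no measured pair shows this exact change, so the step is uncertain. Since compound 2, which also bears a carbonyl-linked group on the ring, shows 94%, a rise is expected, but a smaller one: the estimated step of a number 27 percentage points higher from compound 1 to compound 3 (beyond the scatter) places compound 3 at 65%, within 35% to 90%.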

Compound 3, a percentage reported as inhibition, in the whole organism at one dose (the size of the read-out at that dose, not a potency): 43%
Compound 3: middle estimate off by 22 percentage points, on the high side; low and high end bracket the measured number.
By their numbers in this assay, from the lowest: compounds 1 and 3 (each within the scatter of the next); then compound 2.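

In this assay, diethylcarbamoyl in place of allyl on this saturated ring carbon gives a number 5 percentage points higher from compound 1 to compound 3 (within the scatter). The two compounds therefore cannot be told apart on this read-out, even though the entering group brings more heavy atoms and a hydrogen-bond acceptor. Nothing available explains this result.

Compound 2 differs from compound 3 in more than one place, so its number cannot be tied to a single group. On these data alone, it remains open whether an amine or a carboxylic acid on this ring carbon would separate from compound 1.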